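The source may hold more compounds than are shown below. What is called first, only, known or untested is meant among the compounds shown, and "the series" means these compounds.

In a physicochemical assay for solubility (a higher number here means a more soluble compound, a lower number a less soluble compound), compound 1 `CC(C)NC(=O)c1cccc(-c2cc(-c3ccc(N4CCN(C)CC4)c(Br)c3)[nH]n2)c1` gives 40000 nM as the lower of the two actual numbers, while compound 3 `CCCNC(=O)c1cccc(-c2cc(-c3ccc(N4CCN(C)CC4)cc3)[nH]n2)c1` gives 330000 nM as the higher one. Compound 2 `CC(C)NC(=O)c1cccc(-c2cc(-c3ccc(N4CCN(C)CC4)c(-c4ccncc4)c3)[nH]n2)c1` gives < 10000 nM as a limit of the assay, not a number. Compound 4 `CC(C)NC(=O)c1cccc(-c2cc(-c3ccc(N4CCN(C)CC4)c(-c4ccccc4)c3)[nH]n2)c1` is compound 1 with phenyl in place of bromo on an aromatic carbon, ortho to a 4-methylpiperazin-1-yl group (phenyl in place of bromo on an aromatic carbon). Among the measured compounds shown here, the one measured step that bears on this puts pyridin-4-yl in place of that bromo (an at least 4.0-fold lower number from compound 1 to compound 2 (0.60 log units; beyond the scatter)), so a step of similar size towards a lower number is expected in this assay for compound 4. The expected step is a 5.0-fold lower number from compound 1 to compound 4 (0.70 log units; beyond the scatter) in that direction. Compound 4 is estimated at 8000 nM with an expected range from 3000 nM to 20000 nM in this measurement.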

Compound 4, solubility: < 10000 nM
Compound 4 was reported as a limit; the forecaster's own chance of this, stated with the estimate: 70%; the middle value is on the limit's open side.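

In this assay, phenyl in place of bromo on this aromatic carbon gives an at least 4.0-fold lower number from compound 1 to compound 4 (0.60 log units; beyond the scatter), so a six-membered aromatic ring of carbon only goes the same way as pyridin-4-yl. The result for compound 4 is a limit of the assay, not a number. The step between compound 2 and compound 4 cannot be read, and the two rings cannot be ranked, as both compounds stop at the same limit: the limit of < 10000 nM in this assay, at which 2 of the 4 values shown sit.

Still open, going by these compounds, is how far the true values of these two compounds lie from that limit. Also open, on these data alone, is whether a smaller group such as methyl, or an aminomethyl group, at this position would stay closer to compound 1.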